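The source may report more compounds than this note shows. Statements on the series, on what has been measured and on what is new or still open speak of the compounds shown alone.

In a functional assay on PC-3 cells (Homo sapiens) for antiproliferative activity, read by CCK-8 assay, with a stated time of 72 h (a higher number here means a weaker inhibitor, a lower number a stronger inhibitor), three compounds sharing one core have been measured. Compound 1 `Cc1cc(Nc2cc(N3CCN(C)CC3)nc(Nc3ccc([N+](=O)[O-])cc3)n2)n[nH]1` gives 1090 nM, compound 2 `Cc1cc(Nc2cc(N3CCN(C)CC3)nc(Nc3cccc([N+](=O)[O-])c3)n2)n[nH]1` gives 962 nM, and compound 3 `Cc1cc(Nc2cc(N3CCN(C)CC3)nc(Nc3ccc(C#N)cc3)n2)n[nH]1` gives 977 nM, so compound 3 stands level with the other two within the scatter. Compound 4 `COc1ccc(Nc2nc(Nc3cc(C)[nH]n3)cc(N3CCN(C)CC3)n2)cc1` carries methoxy in place of cyano on an aromatic carbon, para to a large group (methoxy in place of cyano on an aromatic carbon). Within the data shown here, the steps that bear on this are a 1.1-fold lower number from compound 1 to compound 3 (0.05 log units; within the scatter) and a 1.0-fold higher number from compound 2 to compound 3 (0.01 log units; within the scatter), together with a 1.1-fold lower number from compound 1 to compound 2 (0.05 log units; within the scatter), and none leaves the scatter. Methoxy itself has no measured precedent here, so no step beyond the scatter is expected in this assay. The estimated step is a 1.0-fold higher number from compound 3 to compound 4 (0.01 log units; within the scatter). For compound 4 the expected value is 1000 nM, with an estimated range of 420 nM to 2400 nM.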

Compound 4, half-maximal inhibitory concentration: 2000 nM
The estimate for compound 4 lay 2.0-fold (0.30 log units) below the measured number; low and high end bracket the measured number.
By their numbers in this assay, from the lowest: compounds 2, 3, 1 and 4 (each within the scatter of the next, the first and the last beyond it).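

In this assay, among these compounds, methoxy, on an aromatic carbon para to a large group, is the only group here with steps beyond the scatter: the change gives a 2.0-fold higher number from compound 3 to compound 4 (0.31 log units; beyond the scatter) and the comparison with the 3-nitrophenyl compound gives a 2.1-fold higher number from compound 2 to compound 4 (0.32 log units; beyond the scatter) while a 1.8-fold higher number from compound 1 to compound 4 (0.26 log units; within the scatter) stays within the scatter. This position is therefore not wholly indifferent to its substituent, which the nitro and cyano compounds alone could not show. As far as these compounds go, whether a hydroxyl, an amine or a chlorine here would follow methoxy or stay level with nitrile remains open. No measured evidence accounts for these steps.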